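The compounds below may be only part of what the source reports. "The series", "measured", "known", "first", "only" and "open" are said of these compounds alone.

Compound 1, with structure `CCOC(=O)C1=C(C)N(C)C(=O)NC1c1ccco1`, gives 25% in an assay on HeLa cells for displacement of a labelled ligand from adenosine receptor A3 (Homo sapiens), with a stated time of 180 min, tested at 10 uM; on this read-out lower numbers stand for less inhibition and higher numbers for more inhibition at the one concentration tested (going by the name of the read-out). Going by the values given here, it stands highest of the two numbers measured so far, though its nearest neighbour is within the scatter: compound 2, with structure `CC1=C(C(=O)OC(C)C)C(c2ccco2)NC(=O)N1C`, gives 18% in this assay, and the step of a number 7 percentage points lower from compound 1 to compound 2 (within the scatter) corresponds to a methyl in place of hydrogen on a saturated chain carbon bound to an oxygen next to a carbonyl group and a saturated chain carbon. Compound 3, with structure `CCOC(=O)C1=C(C)N(C)C(=O)NC1c1ccoc1`, has not yet been measured in this assay. It differs from compound 1 by furan-3-yl in place of furan-2-yl on a saturated ring carbon, so the change sits on a saturated ring carbon of the shared core rather than on the ester. Among the compounds with values here, no measured step touches that part of the molecule, and the one step that has been measured, from compound 1 to compound 2, stayed within the scatter. Without any comparable precedent, compound 3 is expected to land close to compound 1, with a step of a number 1 percentage points lower from compound 1 to compound 3 (within the scatter) that is estimated to lie within the scatter. For compound 3 the expected value in this assay is therefore 24%, within a range from 5% to 45%.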

Compound 3, a percentage reported as inhibition, at one concentration (the size of the read-out at that concentration, not a potency): 1%
Estimate against measurement, compound 3: 23 percentage points above, and the stated range ends above it.
By their numbers in this assay, from the lowest: compound 3; then compounds 2 and 1 (each within the scatter of the next).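

The position carrying the furan ring proved sensitive in this assay, where exchanging furan-2-yl for furan-3-yl on the saturated ring carbon gave a number 24 percentage points lower from compound 1 to compound 3 (beyond the scatter). This change leaves the heavy atoms, hydrogen-bond donor and acceptor counts and net charge of the group as they were and alters only how the furan ring is joined to the shared core, so the connection point of the ring matters here even though the atoms themselves stay the same; the earlier step on the ester, a number 7 percentage points lower from compound 1 to compound 2 (within the scatter), had shown no such sensitivity at its own position. Nothing shown here accounts for the size of the step on the furan ring.

The compounds shown leave open whether the same step would appear with the ester of compound 2 in place of the ethoxycarbonyl group, since only the ethyl ester is shown with furan-3-yl. They also leave open how a phenyl ring, a thiophen-2-yl group or a simple alkyl chain on the same saturated ring carbon would compare with furan-2-yl in this assay, and, as every number comes from a single concentration, how potency differs across the series.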